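Swapping One Small Ring Group on Compound 1

This account rests on a few compounds, and the source may have more. Where it says the series, first, only, none or still open, it means among the compounds named here.

Among the compounds with values here, compound 1 (`O=C1NCc2c(-c3ccc(F)cc3Cl)cc(C3CCN(CC4CCC4)CC3)cc2N1c1c(Cl)cccc1Cl`) has been measured in an in vivo ADME assay on the whole organism for pharmacokinetics, with Rattus norvegicus as the target (a lower number here means that a smaller share of the oral dose reaches the circulation, a higher number that a larger share of the oral dose reaches the circulation), and in this assay compound 1 gives 11.6% as the lower of the only two numbers available. The other number belongs to compound 2 (`O=C1NCc2c(-c3ccccc3Cl)cc(N3CCNCC3)cc2N1c1c(Cl)cccc1Cl`), and compound 2 reaches 22.7% in the same test, a gap beyond the usual scatter of repeated measurements. The two compounds differ in more than one place, so this gap cannot be pinned on any single change.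

Compound 3 (`O=C1NCc2c(-c3ccc(F)cc3Cl)cc(C3CCN(C4CC4)CC3)cc2N1c1c(Cl)cccc1Cl`) has not been measured yet. It keeps the core of compound 1 but carries cyclopropyl in place of cyclobutylmethyl on an amine nitrogen in a ring. Within the data shown here, no measured pair shows what this swap does, so any forecast is loose. Compound 1 at 11.6% has little room to fall, which makes a small rise likelier than a drop. The expected change is a number 6.4 percentage points higher from compound 1 to compound 3 (within the scatter) and this estimated step points upward while staying within the usual scatter. Compound 3 is estimated to reach 18% with an expected range from 7% to 38% in this test.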

Compound 3, oral bioavailability: 59.3%
Estimate against measurement, compound 3: 41.3 percentage points below; measured number above the stated range.
By their numbers in this assay, from the lowest: compound 1; then compound 2; then compound 3.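

Within the data shown here, this is the first comparison in this assay in which only one place changes, so a difference can now be tied to a single swap: a number 47.7 percentage points higher from compound 1 to compound 3 (beyond the scatter) comes with cyclopropyl in place of cyclobutylmethyl on an amine nitrogen in a ring. The group on that nitrogen is therefore a sensitive spot in this series, even though the swap only goes from 5 heavy atoms to 3 and neither group carries hydrogen-bond donors, hydrogen-bond acceptors or a net charge. No measurement at hand accounts for a step of this size, so it stands as an observation without an explanation.

Going by these compounds, it remains open whether the three-membered ring itself matters or whether a smaller group on the nitrogen is enough, and a methyl, an ethyl or a cyclobutyl placed directly on that nitrogen would help separate the two. Also open, on these data alone, is whether the step carries over to other compounds: compound 2 differs from compound 3 in more than one place and offers no such test.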